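A few compounds are considered here, and "the series" means these few. Any claim that something is new, unique, unknown or untested is made for them only; others in the source may bear on it.

Going by the values given here, in a functional assay on B16-F10 cells (Mus musculus) for antiproliferative activity, read by MTT assay, with a stated time of 48 h (a lower number here means a stronger inhibitor, a higher number a weaker inhibitor), three compounds with a shared core have numbers so far. Compound 1 `CC(=O)N1N=C(c2ccc3ccccc3c2)OC1c1ccccc1` gives 2.57 ug/mL and compound 2 `CC(=O)N1N=C(c2ccc3ccccc3c2)OC1c1ccc(Cl)cc1` gives 2.48 ug/mL, and the chloro replacement separating them is a 1.0-fold lower number from compound 1 to compound 2 (0.02 log units; within the scatter). Compound 3 `CC(=O)N1N=C(c2ccc3ccccc3c2)OC1c1ccccc1F` gives 6.05 ug/mL, the highest number of the three, which makes it the weakest inhibitor in this small set. Two measured steps lead to it: a 2.4-fold higher number from compound 1 to compound 3 (0.37 log units; beyond the scatter) and a 2.4-fold higher number from compound 2 to compound 3 (0.39 log units; beyond the scatter).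

Compound 4 `CC(=O)N1N=C(c2ccc3ccccc3c2)OC1c1cccc(F)c1` has not yet been measured. It differs from compound 3 as follows: 3-fluorophenyl in place of 2-fluorophenyl on a saturated ring carbon. In words, 3-fluorophenyl stands in place of 2-fluorophenyl on a saturated ring carbon.

Among the compounds with values here, no measured compound carries the 3-fluorophenyl group, so the evidence is indirect. The most relevant step is the fluoro replacement, a 2.4-fold higher number from compound 1 to compound 3 (0.37 log units; beyond the scatter), since it gives the only measured effect of a fluoro group in this set. It also bounds the likely movement, so a partial return toward the number of compound 1 seems a reasonable expectation. The expected change is a 1.5-fold lower number from compound 3 to compound 4 (0.18 log units; within the scatter) in this assay, towards a lower number. Compound 4 is estimated at 4 ug/mL, with an expected range from 2 ug/mL to 8 ug/mL on the same read-out.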

Compound 4, half-maximal inhibitory concentration: 1.61 ug/mL
Estimate against measurement, compound 4: 2.5-fold (0.40 log units) above; measured number outside the range, below it.
By their numbers in this assay, from the lowest: compounds 4, 2 and 1 (each within the scatter of the next); then compound 3.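

In this assay the exchange of 2-fluorophenyl for 3-fluorophenyl on the saturated ring carbon gives a 3.8-fold lower number from compound 3 to compound 4 (0.57 log units; beyond the scatter) and lies beyond the scatter, although the two compounds have the same atoms, so in this set the outcome of adding a fluoro group depends on where it stands and not on its presence alone. The earlier fluoro step suggested a penalty for that replacement, yet here the step is a 1.6-fold lower number from compound 1 to compound 4 (0.20 log units; within the scatter) and the comparison with the chloro compound is a 1.5-fold lower number from compound 2 to compound 4 (0.19 log units; within the scatter), both within the scatter, which leaves 3-fluorophenyl, 4-chlorophenyl and the plain phenyl of compound 1 indistinguishable and only 2-fluorophenyl apart from them. Nothing available here accounts for this difference between the two fluorophenyl groups.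

The compounds shown leave open whether a chloro group in the place the fluoro holds in 2-fluorophenyl would also give a higher number, and whether a methoxy group or an amine in the place it holds in 3-fluorophenyl would stay level with compound 4. They also leave open how far these steps carry over if the acetyl group, unchanged throughout, gives way to a longer chain.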